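Trifluoromethyl for chloro on the fused ring of compound 1

A few compounds are considered here, and "the series" means these few. Any claim that something is new, unique, unknown or untested is made for them only; others in the source may bear on it.

Within the data shown here, compound 1 `NC(=S)N/N=C1/C(=O)N(CN2CCN(c3ccnc4cc(Cl)ccc34)CC2)c2cccc(Br)c21` and compound 2 `NC(=S)N/N=C1/C(=O)N(CN2CCN(c3ccnc4cc(Cl)ccc34)CC2)c2ccccc21` are the two measured members; in an ADME assay on 184B5 cells (Homo sapiens) for cytotoxicity, read by sulforhodamine B assay, with a stated time of 48 h (a higher number here means a weaker inhibitor of growth, a lower number a stronger inhibitor of growth), compound 1 gives 46400 nM, and compound 2 gives 28800 nM. Among the measured compounds shown here, the only single-place step so far, hydrogen in place of bromo on an aromatic carbon, is a 1.6-fold lower number from compound 1 to compound 2 (0.21 log units; within the scatter). Compound 3 `NC(=S)N/N=C1/C(=O)N(CN2CCN(c3ccnc4cc(C(F)(F)F)ccc34)CC2)c2cccc(Br)c21` carries trifluoromethyl in place of chloro on an aromatic carbon. For the measured compounds named here, no measured step touches this position, and the one known step lies within the scatter, so no step beyond the scatter is expected in this assay. For compound 3 the estimate is 46000 nM, range 20000 nM to 105000 nM, a step of a 1.0-fold lower number from compound 1 to compound 3 (0.00 log units; within the scatter).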

Compound 3, concentration for 50% growth inhibition: 26400 nM
Beside the measured number, compound 3's estimate is 1.7-fold (0.24 log units) above it, within the range that was stated.
By their numbers in this assay, from the lowest: compounds 3, 2 and 1 (each within the scatter of the next).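

At this aromatic carbon, in this assay, a larger group is tolerated without a step beyond the scatter: trifluoromethyl in place of chloro gives a 1.8-fold lower number from compound 1 to compound 3 (0.24 log units; within the scatter), with 4 heavy atoms entering where 1 leaves. Among these compounds, this is the first reading at this position, and it shows that the number does not depend on chloro being there, at least against the bromo background of compound 1. No measurement bears on what lies behind this step. As far as these compounds go, whether an amine or a carboxylic acid on this carbon would give a step beyond the scatter remains open. So does whether trifluoromethyl gives the same result on compound 2, which lacks bromo.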